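The compounds below may be only part of what the source reports. "The series", "measured", "known", "first", "only" and "open" are said of these compounds alone.

Compound 1 `Cc1cc(C)n2nc(SCc3nnc(SCc4coc5ccccc5c4=O)n3-c3ccccc3)nc2n1` gives 16600 nM in a functional assay on LM7 cells (Homo sapiens) for cytotoxicity, read by MTT assay, with a stated time of 72 h; on this read-out higher numbers stand for weaker inhibition and lower numbers for stronger inhibition.
Compound 2 `Cc1nnc(SCc2cc(=O)c3cc(Cl)ccc3o2)o1` reaches only the assay limit of > 25000 nM in this assay.
Compound 3 `Cc1nnc(SCc2cc(=O)c3ccccc3o2)o1` likewise reaches only the assay limit of > 25000 nM in this assay.

Compound 2 stands at a limit, not a number, and the limit of > 25000 nM in this assay, at which 2 of the 3 values shown sit, shows compound 3 at the same limit. Among the compounds with values here, the single measured step, a step that the two limits leave unreadable from compound 2 to compound 3, is thus of unreadable size. Compound 4 `Nc1nnc(SCc2cc(=O)c3cc(Cl)ccc3o2)s1` differs from compound 2 by 5-amino-1,3,4-thiadiazol-2-yl in place of 5-methyl-1,3,4-oxadiazol-2-yl on a sulfur. Within the data shown here, no measured step bears on this exchange on the sulfur, so the available data give no direction for it. The step from compound 2 to compound 4 is expected to be an at least 1.1-fold lower number from compound 2 to compound 4 (0.05 log units; that floor lies within the scatter), with nothing beyond the scatter foreseen. Compound 4 is estimated at 22000 nM, ranging from 8000 nM to 60000 nM, and quite possibly again only a limit.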

Compound 4, half-maximal inhibitory concentration: > 25000 nM
Compound 4: a limit, no number; the forecaster's own chance of this, stated with the estimate: 60%; middle value at least 1.1-fold (0.05 log units) from the limit.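

Compound 2 and compound 4 give no number, and no step can be read between them because each stands at a limit: the limit of > 25000 nM in this assay, at which 3 of the 4 values shown sit.

The compounds shown leave open whether 5-amino-1,3,4-thiadiazol-2-yl in place of 5-methyl-1,3,4-oxadiazol-2-yl on a sulfur changes cytotoxicity at all.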